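A few compounds are considered here, and "the series" means these few. Any claim that something is new, unique, unknown or untested is made for them only; others in the source may bear on it.

Measured in a functional assay on DU-145 cells (Homo sapiens) for inhibition, read by CCK-8 assay, with a stated time of 72 h; on this read-out higher numbers stand for weaker inhibition and lower numbers for stronger inhibition:
- compound 1 `Cc1ccccc1NS(=O)(=O)c1cccc(CCCCCCNC(=O)/C=C/c2cccnc2)c1`: 2.9 nM
- compound 2 `Cc1ccc(C)c(NS(=O)(=O)c2cccc(CCCCCCNC(=O)/C=C/c3cccnc3)c2)c1`: 7.48 nM

Of these two, compound 2 at 7.48 nM has the higher number and so the weaker inhibition in this assay.

The next compound is compound 3 `O=C(/C=C/c1cccnc1)NCCCCCCc1cccc(S(=O)(=O)Nc2ccc(Cl)cc2)c1`, which has 4-chlorophenyl in place of 2,5-dimethylphenyl on a sulfonamide nitrogen.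

Among the measured compounds shown here, only one measured step bears on this change. It is a 2.6-fold higher number from compound 1 to compound 2 (0.41 log units; beyond the scatter), a modest step that comes from methyl in place of hydrogen on an aromatic carbon within the group that now changes. The group entering in compound 3 carries no methyl, so this step leans weakly toward a lower number. For the measured compounds named here, no measured compound carries chlorine, however, and one step sets no rule, so the direction remains tentative.

The expected change is a 1.5-fold lower number from compound 2 to compound 3 (0.17 log units; within the scatter), a small move toward a lower number that is not clearly beyond the scatter.

For compound 3 the estimated value is 5 nM, with an expected range of 1.5 nM to 16 nM.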

Compound 3, half-maximal inhibitory concentration: 84.4 nM
Compound 3: the middle estimate sits 17-fold (1.23 log units) below what was measured; the whole stated range lies below it.
By their numbers in this assay, from the lowest: compound 1; then compound 2; then compound 3.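

In this assay, among the compounds shown here, the group on the sulfonamide nitrogen proves far more sensitive than the single methyl change suggested: against the modest 2.6-fold higher number from compound 1 to compound 2 (0.41 log units; beyond the scatter), 4-chlorophenyl in place of 2,5-dimethylphenyl gives an 11-fold higher number from compound 2 to compound 3 (1.05 log units; beyond the scatter), and 4-chlorophenyl in place of 2-methylphenyl gives a 29-fold higher number from compound 1 to compound 3 (1.46 log units; beyond the scatter). Among these three compounds, the two methyl-bearing groups stay much closer to each other than either does to 4-chlorophenyl, so adding a methyl is not a reliable guide to what happens when the group is exchanged as a whole. Each large step removes methyl and introduces chlorine together, so the loss cannot be assigned to either change, and no supporting data explain it.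

Still open, from the compounds shown here alone, is whether the loss follows the chlorine, the absence of methyl or the position of substitution; plain phenyl and 4-methylphenyl on the sulfonamide nitrogen would help separate these readings. Also open is whether the same order among these groups would hold with a longer chain in the shared core.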